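This account rests on a few compounds, and the source may have more. Where it says the series, first, only, none or still open, it means among the compounds named here.

Measured so far in a functional assay on HL-60 cells (Homo sapiens) for cytotoxicity, read by MTT assay, with a stated time of 4 days; on this read-out lower numbers stand for stronger inhibition and higher numbers for weaker inhibition:
compound 1 `C=C1C(=O)[C@]23C[C@@]1(O)CC[C@H]2c1ccc(O)c(C)c1[C@@H]3Cn1cc(-c2ccccn2)nn1`: 1970 nM
compound 2 `C=C1C(=O)[C@]23C[C@@]1(O)CC[C@H]2c1ccc(O)c(C)c1[C@@H]3Cn1cc(-c2ccc(C(F)(F)F)cc2)nn1`: 720 nM

Going by the values given here, compound 2 holds the lowest of the two numbers in this assay; the only other measured compound, compound 1, sits higher, the difference being a 2.7-fold lower number from compound 1 to compound 2 (0.44 log units; beyond the scatter), a modest step.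

Compound 3 `C=C1C(=O)[C@]23C[C@@]1(O)CC[C@H]2c1ccc(O)c(C)c1[C@@H]3Cn1cc(-c2ccc(C)cc2)nn1` differs from compound 2 by methyl in place of trifluoromethyl on an aromatic carbon, on an aromatic carbon of a six-membered aromatic ring of carbon only, para to a large group; cut one bond further out, the change reads 4-(trifluoromethyl)phenyl to 4-methylphenyl.

Among the compounds with values here, no measured step bears directly on this change. Within the data shown here, the single step in hand swaps pyridin-2-yl for 4-(trifluoromethyl)phenyl, altering the ring and the substituent together. Among the measured compounds shown here, no measured pair keeps the ring and exchanges only the para group. With the ring kept and only the para group exchanged, no step beyond the scatter is expected in this assay, though a drift toward a somewhat higher number would not be surprising.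

Compound 3 is estimated at 1000 nM, with a range from 400 nM to 2600 nM. The expected step is a 1.4-fold higher number from compound 2 to compound 3 (0.14 log units; within the scatter).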

Compound 3, half-maximal inhibitory concentration: 830 nM
Compound 3: the middle estimate sits 1.2-fold (0.08 log units) above what was measured, within the range that was stated.
By their numbers in this assay, from the lowest: compounds 2 and 3 (each within the scatter of the next); then compound 1.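

In this assay, replacing trifluoromethyl with methyl on this aromatic carbon, para to a large group, gives a 1.2-fold higher number from compound 2 to compound 3 (0.06 log units; within the scatter), so this position tolerates the exchange of these two groups, which differ in heavy-atom count, without a change that can be read beyond the scatter. The second new step, a 2.4-fold lower number from compound 1 to compound 3 (0.38 log units; beyond the scatter), is of modest size and similar in reading to the earlier step from the pyridin-2-yl compound, so the separation from compound 1 is now seen with two different para groups and no longer rests on trifluoromethyl alone. Nothing at hand gives a measured explanation for either step.

Still open, as far as these compounds go, is whether the separation from compound 1 belongs to the carbon-only ring itself or also requires a group in this place, a question that a plain phenyl would address. From the compounds shown here alone, it is equally open whether the tolerance extends beyond these two small groups, for instance to an amine, a carboxylic acid or a longer alkyl chain on the same aromatic carbon.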